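The source may hold more compounds than are shown below. What is called first, only, known or untested is meant among the compounds shown, and "the series" means these compounds.

In a functional assay on the whole organism for antagonist activity, with Mus musculus as the target (on this read-out lower numbers stand for an effect already at smaller amounts and higher numbers for an effect only at larger amounts of compound), compound 1 `COc1cc(N)c(Cl)cc1NC(=O)C1CCN(Cc2ccc(Cl)cc2)CC1` gives 1.2 mg/kg. Compound 2 `COc1ccc(CN2CCC(C(=O)Nc3cc(Cl)c(N)cc3OC)CC2)cc1` gives 0.9 mg/kg. Compound 3 `COc1cc(N)c(Cl)cc1NC(=O)C1CCN(Cc2ccc([N+](=O)[O-])cc2)CC1` gives only a limit of this assay, > 4 mg/kg.

Compound 1 has the higher of the two plain numbers, but its step to compound 2, a 1.3-fold lower number from compound 1 to compound 2 (0.12 log units; within the scatter), lies within the scatter. Compound 4 `CCC(CC)CN1CCC(C(=O)Nc2cc(Cl)c(N)cc2OC)CC1` differs from compound 1 in this way: pentan-3-yl in place of 4-chlorophenyl on a saturated chain carbon bound to an amine nitrogen in a ring. Among the measured compounds shown here, no measured step touches this change. The measured steps swap a single substituent on the aromatic ring that here leaves altogether; an at least 3.3-fold higher number from compound 1 to compound 3 (0.52 log units; beyond the scatter) and an at least 4.4-fold higher number from compound 2 to compound 3 (0.64 log units; beyond the scatter) show that even such a swap can shift the number beyond the scatter, and one of the values is a limit (the limit of > 4 mg/kg in this assay, at which 1 of the 3 values shown sits). For compound 4 the estimate is therefore cautious: 2.5 mg/kg, ranging from 0.8 mg/kg to 8 mg/kg. This expected step, a 2.1-fold higher number from compound 1 to compound 4 (0.32 log units; beyond the scatter), is uncertain in either direction.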

Compound 4, dose for half-maximal effect: > 10 mg/kg
Compound 4 ended at the assay's limit; the forecaster's own chance of this, stated with the estimate: 30%; middle value at least 4.0-fold (0.60 log units) from the limit.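

Swapping the aromatic ring at this place for the open-chain pentan-3-yl group gives an at least 8.3-fold higher number from compound 1 to compound 4 (0.92 log units; beyond the scatter) and an at least 11-fold higher number from compound 2 to compound 4 (1.04 log units; beyond the scatter), a change far larger than the scatter. Compound 4 gives > 10 mg/kg, which is a limit of this assay. Compound 3 keeps an aromatic ring yet also gives a limit, > 4 mg/kg, and the step from compound 3 to compound 4 cannot be read.

From the compounds shown here alone, whether the aromatic ring as such matters stays open; a cyclohexyl group or an unsubstituted phenyl at this place would speak to that.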